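The source may report more compounds than this note shows. Statements on the series, on what has been measured and on what is new or still open speak of the compounds shown alone.

Measured so far:
Compound 1, `Cc1ccc(-c2ccnc(C(=O)Nc3ccc(Oc4ccnc5[nH]ccc45)cc3)c2)cc1` — in a functional assay on PC-3 cells (Homo sapiens) for cytotoxicity, read by MTT assay, with a stated time of 72 h (on this read-out higher numbers stand for weaker inhibition and lower numbers for stronger inhibition), compound 1 gives > 10000 nM, which is a limit of the assay and not a number.
Compound 2, `O=C(Nc1ccc(Oc2ccnc3[nH]ccc23)cc1)c1cc(-c2ccccc2)ccn1` — compound 2 gives 3270 nM.
Compound 3, `O=C(Nc1ccc(Oc2ccnc3[nH]ccc23)c(F)c1)c1ccc(-c2ccccc2)cn1` — compound 3 gives 760 nM.

Compound 3 returns the lower of the two numbers recorded; its nearest neighbour is compound 2, and the gap between them lies beyond the scatter. How the cores of compound 2 and compound 3 differ is not broken down here.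

One change is seen twice in the set. Between compound 2 and compound 1 it is methyl in place of hydrogen on an aromatic carbon and it gave an at least 3.0-fold higher number from compound 2 to compound 1 (0.48 log units; beyond the scatter); compound 1 sits at the limit of > 10000 nM in this assay, at which 1 of the 3 values shown sits, so only the floor of that step is known.

Compound 4, `Cc1ccc(-c2ccc(C(=O)Nc3ccc(Oc4ccnc5[nH]ccc45)c(F)c3)nc2)cc1`, is not yet measured. It differs from compound 3 by methyl in place of hydrogen on an aromatic carbon, the same change as that between compound 2 and compound 1, made on the same kind of position. Resting on the step from compound 2 to compound 1 given by an at least 3.0-fold higher number from compound 2 to compound 1 (0.48 log units; beyond the scatter), compound 4 is expected to show a 3.9-fold higher number from compound 3 to compound 4 (0.60 log units; beyond the scatter) in this assay. For compound 4 the estimate is 3000 nM, expected between 1000 nM and 10000 nM.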

Compound 4, half-maximal inhibitory concentration: 2640 nM
Compound 4: middle estimate off by 1.1-fold (0.06 log units), on the high side, within the range that was stated.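

In this assay the change from phenyl to 4-methylphenyl gives a 3.5-fold higher number from compound 3 to compound 4 (0.54 log units; beyond the scatter) on the core of compound 3, so the higher number seen on the core of compound 2 recurs here, and on these two cores the change runs the same way. This does not show that the change carries over with the same size, and it says nothing of cores beyond these two: the same change on two cores in this assay, an at least 3.0-fold higher number (0.48 log units; beyond the scatter) from compound 2 to compound 1 and a 3.5-fold higher number (0.54 log units; beyond the scatter) from compound 3 to compound 4; the limit leaves it open whether they differ. Compound 1 gives > 10000 nM, which is a limit of the assay and not a number, so its step has a floor and no measured size: the limit of > 10000 nM in this assay, at which 1 of the 4 values shown sits.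

The compounds shown hold only hydrogen and methyl at this place on the aromatic ring, which leaves open how an ethyl, a methoxy, an amine or a carboxylic acid there would read in this assay. Also open, on these data alone, is which of the differences between the cores of compound 2 and compound 3 bears on the number, since those cores differ in more than one place.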